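The compounds below may be only part of what the source reports. "The series", "measured", "known", "first", "only" and "open" are said of these compounds alone.

Working notes on the series. For the measured compounds named here, in an ADME assay on MT4 cells (Homo sapiens) for cytotoxicity, read by MTT assay, with a stated time of 5 days (a higher number here means that more compound is tolerated, a lower number that less compound is tolerated), compound 1 (`Cc1cc(/C=C/C#N)cc(C)c1Oc1cc(NCCN(C)C)nc(Nc2ccc(C#N)cc2)n1`) gives 3040 nM and compound 2 (`C=CCNc1cc(Oc2c(C)cc(/C=C/C#N)cc2C)nc(Nc2ccc(C#N)cc2)n1`) gives 3050 nM in the same test, so compound 2 stands level with the only other measured number. Compound 3 (`Cc1cc(/C=C/C#N)cc(C)c1Oc1cc(Cl)nc(Nc2ccc(C#N)cc2)n1`) carries chloro in place of allylamino on an aromatic carbon. Going by the values given here, one measured step bears on this change (a 1.0-fold higher number from compound 1 to compound 2 (0.00 log units; within the scatter)), and it puts vinyl in place of (dimethylamino)methyl on a saturated chain carbon. That step keeps the nitrogen on the aromatic ring, whereas the change to compound 3 removes it, so it is only a weak guide. No step beyond the scatter is expected in this assay for this change, with wide uncertainty. The expected step is a 1.0-fold lower number from compound 2 to compound 3 (0.01 log units; within the scatter) on this estimate. For compound 3 the estimate is 3000 nM with an expected range from 1000 nM to 10000 nM in this test.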

Compound 3, half-maximal cytotoxic concentration: 4310 nM
Compound 3: middle estimate off by 1.4-fold (0.16 log units), on the low side; the range from low to high includes it.
By their numbers in this assay, from the lowest: compounds 1, 2 and 3 (each within the scatter of the next).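

In this assay, the aromatic carbon next to the ring nitrogen need not carry a nitrogen substituent at all: chloro in place of allylamino gives a 1.4-fold higher number from compound 2 to compound 3 (0.15 log units; within the scatter), and chloro in place of (2-(dimethylamino)ethyl)amino gives a 1.4-fold higher number from compound 1 to compound 3 (0.15 log units; within the scatter). The earlier step changed only the end of a chain on a retained nitrogen, whereas here a single chlorine atom replaces the whole substituent, including its hydrogen-bond donor, and all three compounds remain within the scatter of one another. No measurement in hand explains this flat result.

From the compounds shown here alone, whether a carboxylic acid or a morpholine at this carbon would also stay within the scatter remains open. The three compounds also leave open whether chloro would behave the same way with a different group in place of the (4-cyanophenyl)amino group.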